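Swapping the piperidinol of compound 1 for a smaller amine

This account rests on a few compounds, and the source may have more. Where it says the series, first, only, none or still open, it means among the compounds named here.

The series is followed in a functional assay on CHO-K1 cells for antagonist activity at melanin-concentrating hormone receptor 1 (Homo sapiens), read by inositol phosphate accumulation, with stated times of 10 min and 45 min; a lower number here means a stronger inhibitor, a higher number a weaker inhibitor. Compound 1, `COCCC1(O)CCN(c2nc(C)c3cc(NC(=O)/C=C/c4ccc(Cl)cc4)ccc3n2)CC1`, gives 220 nM in this assay, the higher of the two numbers measured here. Compound 2, `COCC(=O)NC1CCN(c2nc(C)c3cc(NC(=O)/C=C/c4ccc(OC(F)(F)F)cc4)ccc3n2)CC1`, gives 14 nM in this assay, a value well beyond the scatter from that of compound 1. The two compounds differ in more than one place, so nothing more than this gap is drawn from the pair.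

Compound 3, `Cc1nc(N(C)C2CCCC2)nc2ccc(NC(=O)/C=C/c3ccc(Cl)cc3)cc12`, has not been measured. It is related to compound 1 by a single change: cyclopentyl(methyl)amino in place of 4-hydroxy-4-(2-methoxyethyl)piperidin-1-yl on an aromatic carbon. Among the measured compounds shown here, no measured pair isolates this exchange, so there is no direct precedent for its effect in this assay. A modest change in either direction, or none beyond the scatter, is expected, reflected in the step of a 1.5-fold lower number from compound 1 to compound 3 (0.17 log units; within the scatter) that is estimated here. Compound 3 is therefore expected to give about 150 nM in this assay, within a range from 40 nM to 600 nM.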

Compound 3, half-maximal inhibitory concentration: 57 nM
For compound 3 the middle estimate is 2.6-fold (0.42 log units) above the measured one; the range from low to high includes it.
By their numbers in this assay, from the lowest: compound 2; then compound 3; then compound 1.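

Among the compounds shown here, replacing 4-hydroxy-4-(2-methoxyethyl)piperidin-1-yl with cyclopentyl(methyl)amino on the aromatic carbon between two ring nitrogen atoms gives a 3.9-fold lower number from compound 1 to compound 3 (0.59 log units; beyond the scatter) in this assay as the first single-place reading at this position. The hydroxy-bearing six-membered ring of compound 1 is thus not required for the number seen with compound 3, whose entering group has 0 hydrogen-bond donors and 1 hydrogen-bond acceptor and a five-membered ring of carbon only. Nothing shown here gives a measured reason for this step.

The compounds shown leave open which part of the exchange carries the step: the ring size, the loss of the hydroxy and 2-methoxyethyl groups, or the methyl on the nitrogen. They also leave open whether an unsubstituted piperidin-1-yl or a dimethylamino group here would stay close to compound 3 or return toward compound 1.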